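The source may hold more compounds than are shown below. What is called first, only, known or untested is meant among the compounds shown, and "the series" means these compounds.

Measured so far:
compound 1, `COc1ccc(C(=O)Nc2ccc3nc(NC(=O)C4CCCCC4)sc3c2)cc1`: 4.9 ug/mL
compound 2, `CC(=O)Nc1nc2ccc(NC(=O)c3c(Cl)cccc3Cl)cc2s1`: 0.6 ug/mL

Both numbers come from a functional assay on WI-38 VA13 cells (Homo sapiens) for cytotoxicity; a higher number here means that more compound is needed for the effect, a lower number that less compound is needed. Going by the values given here, compound 2 stands lowest of the two; compound 1 gives a number higher by a margin beyond the usual scatter, so of this pair compound 2 is the one needing less compound for the effect in this assay.

The next compound, compound 3 `CCCCCNc1nc2ccc(NC(=O)c3c(Cl)cccc3Cl)cc2s1`, keeps everything of compound 2 except one group: pentyl in place of acetyl on a nitrogen on an aromatic ring. Among the compounds with values here, no step of this kind between measured compounds is available, so the size of the change in this assay has to be guessed from the structural change alone. The expectation is a modest step, more likely toward a somewhat higher number than toward a lower one, with wide uncertainty.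

For compound 3 the expected value in this assay is 1 ug/mL, with a range from 0.3 ug/mL to 4 ug/mL. The step this estimate implies, a 1.7-fold higher number from compound 2 to compound 3 (0.22 log units; within the scatter), is expected to stay near the edge of the scatter.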

Compound 3, half-maximal effective concentration: 0.27 ug/mL
For compound 3 the middle estimate is 3.7-fold (0.57 log units) above the measured one, and the stated range ends above it.
By their numbers in this assay, from the lowest: compound 3; then compound 2; then compound 1.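

In this assay, pentyl in place of acetyl on a nitrogen on an aromatic ring gives a 2.2-fold lower number from compound 2 to compound 3 (0.35 log units; beyond the scatter), so the number responds to the group at this position. The effect in this assay also does not depend on keeping the carbonyl of the acetamido group, as the pentylamino compound needs less compound, not more. No measurement at hand bears on the reason for this step.

The change swaps the carbonyl and lengthens the chain at once, so this one step cannot separate the two; a hexanoyl group or an ethyl chain on this nitrogen would do so. Also open, from the compounds shown here alone, is how a free amine, a longer chain or a chain ending in a carboxylic acid would read at this position.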